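Bromo at the para position of the styryl aryl

A few compounds are considered here, and "the series" means these few. Any claim that something is new, unique, unknown or untested is made for them only; others in the source may bear on it.

Measured compounds:
- compound 1 `CC1(C)CCC[C@]2(C)[C@@H](CC[C@@](C)(O)/C=C/c3ccccc3)[C@](C)(O)CC[C@@H]12`, 3150 nM
- compound 2 `CC(C)(C)c1ccc(/C=C/[C@](C)(O)CC[C@@H]2[C@@]3(C)CCCC(C)(C)[C@@H]3CC[C@@]2(C)O)cc1`, 45000 nM
- compound 3 `COc1cccc(/C=C/[C@](C)(O)CC[C@@H]2[C@@]3(C)CCCC(C)(C)[C@@H]3CC[C@@]2(C)O)c1OC`, 3280 nM

In a functional assay on A549 cells (Homo sapiens) for cytotoxicity, read by MTT assay, with a stated time of 48 h (on this read-out lower numbers stand for stronger inhibition and higher numbers for weaker inhibition), compound 1 gives the lowest number of the three, while compound 3 sits within the scatter of it and compound 2 lies far away. The new compound 4 `CC1(C)CCC[C@]2(C)[C@@H](CC[C@@](C)(O)/C=C/c3ccc(Br)cc3)[C@](C)(O)CC[C@@H]12` differs from compound 1 by one change: bromo in place of hydrogen on an aromatic carbon. The change enters on an aromatic carbon of the six-membered carbon ring, para to a large group, the same position that carries the tert-butyl group in compound 2.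

Among the measured compounds shown here, two measured steps bear on this. The step of a 14-fold higher number from compound 1 to compound 2 (1.15 log units; beyond the scatter) shows that placing a bulky group on this ring carbon weakens activity strongly. The step of a 1.0-fold higher number from compound 1 to compound 3 (0.02 log units; within the scatter) shows that substituents at other ring carbons leave the number unchanged. Bromo is a single heavy atom, far smaller than tert-butyl, so a weakening of activity is expected, but a much milder one than seen with compound 2. Compound 4 is therefore estimated at 6000 nM, within 2500 nM to 20000 nM, which corresponds to an expected step of a 1.9-fold higher number from compound 1 to compound 4 (0.28 log units; within the scatter).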

Compound 4, half-maximal inhibitory concentration: 43200 nM
Estimate against measurement, compound 4: 7.2-fold (0.86 log units) below; measured number above the stated range.
By their numbers in this assay, from the lowest: compounds 1 and 3 (each within the scatter of the next); then compounds 4 and 2 (each within the scatter of the next).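

In this assay, bromo on this aromatic carbon gives a 14-fold higher number from compound 1 to compound 4 (1.14 log units; beyond the scatter) and so costs far more than a single heavy atom might suggest, while a 1.0-fold lower number from compound 2 to compound 4 (0.02 log units; within the scatter) leaves it within the scatter of the much larger tert-butyl group, so across these two groups the loss does not follow the number of heavy atoms. The 2,3-dimethoxyphenyl group of compound 3 stays well clear of this loss, with a 13-fold higher number from compound 3 to compound 4 (1.12 log units; beyond the scatter) as the change to 4-bromophenyl, so a substituted ring alone does not bring the number up. Nothing measured for these compounds explains the loss.

As far as these compounds go, whether fluoro, an amine or a carboxylic acid on this same carbon would bring the same loss stays open. So does whether bromo on another carbon of the ring would behave like bromo here.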